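The source may report more compounds than this note shows. Statements on the series, on what has been measured and on what is new or still open speak of the compounds shown alone.

Measured so far:
compound 1 `O=[N+]([O-])c1ccc(CN2CCC(n3cc(CC(OCc4cc(-c5ccc(F)cc5)no4)c4ccc(Br)cc4)nn3)CC2)cc1`: 3000 nM in a functional assay on Caco-2 cells (Homo sapiens) for cytotoxicity, with a stated time of 48 h; a lower number here means a stronger inhibitor, a higher number a weaker inhibitor
compound 2 `N#Cc1cccc(-c2cc(COC(Cc3cn(C4CCN(Cc5ccc([N+](=O)[O-])cc5)CC4)nn3)c3ccc(Br)cc3)on2)c1`: 3000 nM in this assay

Among the measured compounds shown here, compound 1 stands level with compound 2 in this assay; the only measured step, no change at the digits printed from compound 1 to compound 2 (within the scatter), swaps a group on the same aromatic carbon and lies within the scatter. Compound 3 `O=[N+]([O-])c1ccc(CN2CCC(n3cc(CC(OCc4cc(-c5ccccc5Br)no4)c4ccc(Br)cc4)nn3)CC2)cc1` differs from compound 1 by 2-bromophenyl in place of 4-fluorophenyl on an aromatic carbon. For the measured compounds named here, as this is another exchange at that carbon, and the one comparable step showed no change, no step beyond the scatter is expected in this assay, that is no change at the digits printed from compound 1 to compound 3 (within the scatter). Compound 3 is therefore estimated at 3000 nM, with a range from 1200 nM to 7500 nM.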

Compound 3, half-maximal inhibitory concentration: 3000 nM
The estimate for compound 3 equals the measured number at the digits printed; the range from low to high includes it.
By their numbers in this assay, from the lowest: compounds 1, 2 and 3 (each within the scatter of the next).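

In this assay, 2-bromophenyl in place of 4-fluorophenyl gives no change at the digits printed from compound 1 to compound 3 (within the scatter) and 2-bromophenyl in place of 3-cyanophenyl gives no change at the digits printed from compound 2 to compound 3 (within the scatter) on this aromatic carbon of the five-membered ring. The position now holds three substituted phenyl groups, carrying fluorine, nitrile or bromine, and the read-out does not separate them. Nothing available bears on why these values coincide. From the compounds shown here alone, whether a non-aromatic group here, such as an amine or a carboxylic acid, would shift the value remains open. Changes elsewhere on the shared core also remain open.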